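Phenyl replacing 4-nitrophenyl on the piperazine nitrogen

A few compounds are considered here, and "the series" means these few. Any claim that something is new, unique, unknown or untested is made for them only; others in the source may bear on it.

Measured compounds:
- compound 1 `Fc1ccccc1N1CCN(Cn2nc(-c3ccc4c(c3)OCCO4)oc2=S)CC1`: 37300 nM
- compound 2 `COc1cccc(N2CCN(Cn3nc(-c4ccc5c(c4)OCCO5)oc3=S)CC2)c1`: 18000 nM
- compound 3 `O=[N+]([O-])c1ccc(N2CCN(Cn3nc(-c4ccc5c(c4)OCCO5)oc3=S)CC2)cc1`: 31700 nM

All three were read in a functional assay on HeLa cells (Homo sapiens) for antiproliferative activity, read by MTT assay, with a stated time of 48 h; a lower number here means a stronger inhibitor, a higher number a weaker inhibitor. Compound 3 gives the second highest of the three numbers; its nearest neighbour is compound 1, and the two lie within the scatter of each other, as do compound 3 and compound 2. For the measured compounds named here, the only step that stands beyond the scatter is a 2.1-fold lower number from compound 1 to compound 2 (0.32 log units; beyond the scatter), a modest one.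

Compound 4 `S=c1oc(-c2ccc3c(c2)OCCO3)nn1CN1CCN(c2ccccc2)CC1` has not yet been measured. Its difference from compound 3 is hydrogen in place of nitro on an aromatic carbon; cut one bond further out, the change reads 4-nitrophenyl to phenyl.

Going by the values given here, the steps that bear on it are those that change the aryl group on the same ring nitrogen: a 1.2-fold lower number from compound 1 to compound 3 (0.07 log units; within the scatter) and a 1.8-fold higher number from compound 2 to compound 3 (0.25 log units; within the scatter), both within the scatter. Among the compounds with values here, no measured pair removes a substituent from that aryl ring to leave plain phenyl, so the relevant steps speak only for small movement. The expected step is therefore a 1.1-fold lower number from compound 3 to compound 4 (0.02 log units; within the scatter), with no clear direction beyond the scatter. Compound 4 is estimated at 30000 nM, with a range from 12000 nM to 75000 nM.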

Compound 4, half-maximal inhibitory concentration: > 50000 nM
Compound 4 ended at the assay's limit (the forecaster's own chance of this, stated with the estimate: 5%); at least 1.6-fold (0.22 log units) between middle value and limit.
By their numbers in this assay, from the lowest: compounds 2, 3 and 1 (each within the scatter of the next, the first and the last beyond it). At a limit, above all of these: compound 4.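

In this assay compound 4, the plain phenyl member, stands at a limit and not at a number: the limit of > 50000 nM in this assay, at which 1 of the 4 values shown sits.

For the compounds shown here, the one step that clears the scatter is an at least 2.7-fold higher number from compound 2 to compound 4 (0.44 log units; beyond the scatter), with hydrogen in place of methoxy, so this is the first sign that the aryl group on the piperazine nitrogen is not fully interchangeable and that the 3-methoxyphenyl compound holds a real edge over the bare ring. The floors of an at least 1.5-fold higher number from compound 3 to compound 4 (0.19 log units; that floor lies within the scatter) and an at least 1.3-fold higher number from compound 1 to compound 4 (0.12 log units; that floor lies within the scatter) stay within the scatter, so taking away nitro or fluoro has no size that can be read, and the series gives no sign that a bare phenyl improves on any of the three substituted rings.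

As far as these compounds go, how far compound 4 lies past the limit stays unknown, so the true size of all three steps is open. Also open, from the compounds shown here alone, is whether the methoxy edge belongs to the group or to its place on the ring, and how an amine or a carboxylic acid on that ring would read in this assay.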